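The source may hold more compounds than are shown below. What is called first, only, known or untested is meant among the compounds shown, and "the series" means these compounds.

Measured so far:
compound 1 `O=C(CSc1nncnc1-c1cccc2ccccc12)Nc1ccc([N+](=O)[O-])cc1Cl`: 150000 nM
compound 2 `CCOC(=O)c1ccc(NC(=O)CSc2nncnc2-c2cccc3ccccc23)c(Cl)c1`: 150000 nM

In an ADME assay on MT4 cells (Homo sapiens) for cytotoxicity, read by MTT assay (a higher number here means that more compound is tolerated, a lower number that less compound is tolerated), compound 1 gives 150000 nM and compound 2 gives 150000 nM. Compound 1 stands level with compound 2. Going by the values given here, the only measured step, no change at the digits printed from compound 1 to compound 2 (within the scatter), concerns ethoxycarbonyl in place of nitro on an aromatic carbon and is flat.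

Compound 3 `O=C(CSc1nncnc1-c1cccc2ccccc12)Nc1cccnc1Cl` differs from compound 1 by 2-chloropyridin-3-yl in place of 2-chloro-4-nitrophenyl on an amide-type nitrogen. Among the compounds with values here, no measured step alters the group on the amide-type nitrogen, so the flat step at another place is the only guide. For compound 3 the expected step is no change at the digits printed from compound 1 to compound 3 (within the scatter), none beyond the scatter. For compound 3 the estimate is 150000 nM, range 70000 nM to 200000 nM.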

Compound 3, half-maximal cytotoxic concentration: 44000 nM
Compound 3: the middle estimate sits 3.4-fold (0.53 log units) above what was measured; measured number below the stated range.
By their numbers in this assay, from the lowest: compound 3; then compounds 1 and 2 (each within the scatter of the next).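

In this assay, the group on the amide-type nitrogen can move the number: 2-chloropyridin-3-yl in place of 2-chloro-4-nitrophenyl gives a 3.4-fold lower number from compound 1 to compound 3 (0.53 log units; beyond the scatter), whereas ethoxycarbonyl in place of nitro gave no change at the digits printed from compound 1 to compound 2 (within the scatter). This change removes the nitro group and also brings a hetero atom into the ring, so one step cannot separate the two. Still open, going by these compounds, is whether an amine or a carboxylic acid in place of nitro, on the carbon-only ring, would follow compound 3 or compound 1. No evidence on the origin of this step is available.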